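A few compounds are considered here, and "the series" means these few. Any claim that something is new, unique, unknown or untested is made for them only; others in the source may bear on it.

Of the compounds shown here, three of one series have been tested in an ADME assay on PC-3 cells (Homo sapiens) for cytotoxicity, read by WST assay, tested at 100 uM; on this read-out lower numbers stand for less inhibition and higher numbers for more inhibition at the one concentration tested (going by the name of the read-out). Compound 1 `CC(C)(C)OC(=O)c1cccc(NC(=O)C2CCCN(C(=O)c3cc(C(F)(F)F)cc(C(F)(F)F)c3)C2)c1` gives 0% in this assay. Compound 2 `CC(=O)Nc1cccc(C(=O)N2CCCC(C(=O)Nc3ccc(Cl)cc3)C2)c1` gives 4% in this assay, and compound 3 `N#Cc1cccc(C(=O)N2CCCC(C(=O)Nc3ccc(Cl)cc3)C2)c1` gives 0% in this assay. Going by the values given here, the one step between compounds that differ in a single place, a number 4 percentage points lower from compound 2 to compound 3 (within the scatter), lies within the scatter. Compound 1 thus stands level with compound 3 at the digits shown, and the number for compound 2 lies within the scatter of both, so the three measured compounds cannot be told apart on this read-out.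

Compound 4 `C=CCOc1cccc(NC(=O)C2CCCN(C(=O)c3cc(C(F)(F)F)cc(C(F)(F)F)c3)C2)c1` has not yet been measured. It differs from compound 1 in one place: allyloxy in place of tert-butoxycarbonyl on an aromatic carbon. Among the compounds with values here, no measured step touches this part of the shared core; the only step available concerns another position and was itself within the scatter. The numbers therefore give no ground to expect a change beyond the scatter, since every measured compound shows almost no inhibition at the concentration tested. Compound 4 is expected to give 3% in this assay, between -8% and 18%. The step of a number 3 percentage points higher from compound 1 to compound 4 (within the scatter) is accordingly expected to stay within the scatter.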

Compound 4, a percentage reported as inhibition, at one concentration (the size of the read-out at that concentration, not a potency): 0%
For compound 4 the middle estimate is 3 percentage points above the measured one; the range from low to high includes it.
By their numbers in this assay, from the lowest: compounds 1, 3, 4 and 2 (each within the scatter of the next).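

Going by these compounds alone, on the shared core, putting allyloxy in place of tert-butoxycarbonyl on an aromatic carbon gives, in this assay, no change at the digits printed from compound 1 to compound 4 (within the scatter), and this is the first measured step at this position. The exchange takes the substituent from 7 heavy atoms and 2 hydrogen-bond acceptors to 4 heavy atoms and 1 hydrogen-bond acceptor, and a difference of that extent in these counts leaves no mark on this read-out. No supporting measurement bears on this result.

Since this single step shows no change, the compounds shown leave open whether any other group at this position, such as an amine, a carboxylic acid or a longer chain, would move the number beyond the scatter. Also open, going by these compounds, is what this position would show at a concentration other than the one tested, and whether the same picture holds on the shared core once the two trifluoromethyl groups are replaced by, for example, methyl groups.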